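Switching the aryl on the sulfonamide: compound 2 to compound 3

The source may report more compounds than this note shows. Statements on the series, on what has been measured and on what is new or still open speak of the compounds shown alone.

In an ADME assay on the whole organism (Rattus norvegicus, strain Sprague-Dawley) for pharmacokinetics, read by LC-MS, with a stated time of 30 min (on this read-out higher numbers stand for wider distribution into tissues and lower numbers for narrower distribution), compound 1 `N#Cc1ccc(O[C@H]2CN(S(=O)(=O)c3ccc(Cl)cc3)C[C@@]2(O)CO)cc1F` gives 170 L/kg, and compound 2 `N#Cc1ccc(O[C@H]2CN(S(=O)(=O)c3ccc(Cl)cn3)C[C@@]2(O)CO)cc1F` gives 12 L/kg. Compound 2 holds the lower of the two numbers in this assay, the step of a 14-fold lower number from compound 1 to compound 2 (1.15 log units; beyond the scatter) being the only measured one and a large one. Compound 3 `N#Cc1ccc(O[C@H]2CN(S(=O)(=O)c3ccccc3C#N)C[C@@]2(O)CO)cc1F` differs from compound 2 by 2-cyanophenyl in place of 5-chloropyridin-2-yl on a sulfonyl sulfur. For the measured compounds named here, the single measured step shows that exchanging the ring on the sulfonyl sulfur can move this read-out a long way, yet no measured pair matches the present change, so a modest expected rise a 3.3-fold higher number from compound 2 to compound 3 (0.52 log units; beyond the scatter) is set with wide bounds. Compound 3 is estimated at 40 L/kg, in the range 10 L/kg to 160 L/kg.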

Compound 3, volume of distribution at steady state in the Rattus norvegicus assay: 4.6 L/kg
For compound 3 the middle estimate is 8.7-fold (0.94 log units) above the measured one, outside the stated range (below it).
By their numbers in the Rattus norvegicus assay, from the lowest: compound 3; then compound 2; then compound 1.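

In the Rattus norvegicus assay the number fell again (a 2.6-fold lower number from compound 2 to compound 3 (0.42 log units; beyond the scatter)) and stood well under the first compound's (a 37-fold lower number from compound 1 to compound 3 (1.57 log units; beyond the scatter)), so 2-cyanophenyl on the sulfonyl sulfur gives the lowest of the three numbers. In a physicochemical assay for lipophilicity, at pH 7.4 (a higher number here means a more lipophilic compound, a lower number a more polar compound), compound 2 gives 3.4 and compound 3 gives 3.4 (no change at the digits printed from compound 2 to compound 3 (within the scatter)), so this fall came without a difference in that read-out. Nothing measured here explains the fall. On these data alone, whether an amine or a carboxylic acid on this ring would take the number lower stays open, as does how much of the fall belongs to the nitrile and how much to the loss of chlorine.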